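The source may report more compounds than this note shows. Statements on the series, on what has been measured and on what is new or still open speak of the compounds shown alone.

In a functional assay on DU-145 cells (Homo sapiens) for cytotoxicity, read by ELISA, with a stated time of 4 days (on this read-out higher numbers stand for weaker inhibition and lower numbers for stronger inhibition), compound 1 (`Cc1ccsc1-c1cc(-c2ccoc2)cc(-c2ccco2)n1`) gives 30400 nM, compound 2 (`Clc1ccc(-c2cc(-c3ccoc3)cc(-c3ccco3)n2)s1`) gives 17200 nM and compound 3 (`Clc1cccc(-c2cc(-c3ccoc3)cc(-c3ccc(Cl)s3)n2)c1`) gives 23000 nM. Compound 2 thus lies within the scatter of both others, and none of the three stands apart. Compound 4 (`Clc1ccc(-c2cc(-c3ccoc3)cc(-c3ccccn3)n2)s1`) departs from compound 2 in one place, with pyridin-2-yl in place of furan-2-yl on an aromatic carbon. Among the measured compounds shown here, the closest precedent is the change at that same place, where 3-chlorophenyl replaces furan-2-yl, and it gave a 1.3-fold higher number from compound 2 to compound 3 (0.13 log units; within the scatter). For the measured compounds named here, the only other measured step, made at the 5-chlorothiophen-2-yl group, gave a 1.8-fold lower number from compound 1 to compound 2 (0.25 log units; within the scatter). Going by the values given here, neither step leaves the scatter, although no measured compound carries pyridin-2-yl. No change beyond the scatter is therefore expected in this assay, and the estimated step is a 1.0-fold lower number from compound 2 to compound 4 (0.01 log units; within the scatter). Compound 4 is expected at 17000 nM, within an estimated range of 7500 nM to 38000 nM.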

Compound 4, half-maximal inhibitory concentration: 20500 nM
For compound 4 the middle estimate is 1.2-fold (0.08 log units) below the measured one, and the stated range covers the measured number.
By their numbers in this assay, from the lowest: compounds 2, 4, 3 and 1 (each within the scatter of the next).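

Pyridin-2-yl is the second six-membered ring shown at the place next to the ring nitrogen, and it brings a ring nitrogen there for the first time. In this assay the exchange for furan-2-yl gives a 1.2-fold higher number from compound 2 to compound 4 (0.08 log units; within the scatter) and the exchange for 3-chlorophenyl gives a 1.1-fold lower number from compound 3 to compound 4 (0.05 log units; within the scatter) and so neither exchange leaves the scatter, and furan-2-yl, 3-chlorophenyl and pyridin-2-yl cannot be told apart at this place. Nothing available here accounts for this lack of separation.

The compounds shown leave open whether a group without an aromatic ring at this place, such as an amine, a carboxylic acid or a longer alkyl chain, would move the number beyond the scatter. They also leave open whether pyridin-2-yl would behave the same way with a group other than 5-chlorothiophen-2-yl on the core.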